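This account rests on a few compounds, and the source may have more. Where it says the series, first, only, none or still open, it means among the compounds named here.

Measured so far:
compound 1 `O=[N+]([O-])c1ccccc1NN=C(c1ccc(O)cc1)c1ccc(O)cc1` with 2.7 ug/mL
compound 2 `O=[N+]([O-])c1ccc(N/N=C/c2ccc(O)cc2)cc1` with 5 ug/mL

In a functional assay on cells (T-cell, Homo sapiens) for cytotoxicity (on this read-out lower numbers stand for stronger inhibition and higher numbers for weaker inhibition), compound 1 gives 2.7 ug/mL, the lowest of the two numbers recorded. Compound 2 sits nearest, and in this assay compound 2 gives 5 ug/mL; the gap between the two is within the scatter, so the two cannot be put in order. Within the data shown here, no pair of measured compounds differs in one place only, so no measured step is available as a guide.

Compound 3 `O=[N+]([O-])c1ccc(NN=C(c2ccc(O)cc2)c2ccc(O)cc2)c([N+](=O)[O-])c1` has not yet been measured. It is derived from compound 1 by the change (nitro in place of hydrogen on an aromatic carbon), on the ring that already carries a nitro group, at the aromatic carbon meta to that nitro group and para to a large group.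

Among the measured compounds shown here, with no measured step of this kind to lean on, the account can only set an expectation. The step of a 1.1-fold lower number from compound 1 to compound 3 (0.03 log units; within the scatter) is expected to stay within the scatter, with no firm direction. For compound 3 the estimated value in this assay is 2.5 ug/mL, with a range from 0.9 ug/mL to 7 ug/mL.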

Compound 3, half-maximal inhibitory concentration: 3.2 ug/mL
The estimate for compound 3 lay 1.3-fold (0.11 log units) below the measured number, and the stated range covers the measured number.
By their numbers in this assay, from the lowest: compounds 1, 3 and 2 (each within the scatter of the next).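

In this assay, the change of hydrogen to nitro on the aromatic carbon meta to a nitro group and para to a large group gives a 1.2-fold higher number from compound 1 to compound 3 (0.07 log units; within the scatter). Among these compounds, this is the first step that isolates a single place, and it shows that this aromatic carbon can take a nitro group, on a ring that already carries one, without moving the number beyond the scatter. Nothing available bears on why the step is so small, and the step alone offers no explanation.

From the compounds shown here alone, what a different group at this aromatic carbon would do remains open, whether an amine, a carboxylic acid or a methoxy group, so one nitro step cannot show if the position is indifferent to substitution in general or only to this group. Going by these compounds, it also remains open whether the same change would stay within the scatter on a compound other than compound 1, since this single step is the only one that can be read for this change.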